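Replacing the (1H-imidazol-1-yl)methyl arm with an ester

The compounds below may be only part of what the source reports. "The series", "measured", "known", "first", "only" and "open" are said of these compounds alone.

Three compounds of the series have numbers in a functional assay on the whole organism for inhibition, with Cavia porcellus as the target; on this read-out higher numbers stand for an effect only at larger amounts of compound and lower numbers for an effect already at smaller amounts. Compound 1 `COc1ccccc1OCC1SCCN1C(=O)Cn1ccnc1` gives 50 mg/kg, compound 2 `COc1ccc(OCC2SCCN2C(=O)Cn2ccnc2)cc1` gives 48 mg/kg, and compound 3 `O=C(O)CC(=O)N1CCSC1COc1ccccc1O` gives 25 mg/kg. Compound 1 holds the highest of the three numbers, but both other values lie within the scatter of it, so no order among the three can be read from these data.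

Compound 4 `CCOC(=O)C(C)(C)C(=O)N1CCSC1COc1ccccc1OC` has not yet been measured in this assay. It differs from compound 1 in one place: 1-(ethoxycarbonyl)-1-methylethyl in place of (1H-imidazol-1-yl)methyl on a carbonyl carbon. For the measured compounds named here, no pair of measured compounds shows this change on its own, and compound 3, the only measured compound without the (1H-imidazol-1-yl)methyl group, also differs from compound 1 elsewhere in the structure, so its value cannot be split between the two changes.

Going by the values given here, with no single-point precedent, the step is expected to be small, a 1.3-fold lower number from compound 1 to compound 4 (0.10 log units; within the scatter), with no clear direction beyond the scatter. Compound 4 is therefore expected to give about 40 mg/kg in this assay, within a range from 15 mg/kg to 120 mg/kg.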

Compound 4, dose for half-maximal effect: 61 mg/kg
Compound 4: middle estimate off by 1.5-fold (0.18 log units), on the low side; measured number inside the range.
By their numbers in this assay, from the lowest: compounds 3, 2, 1 and 4 (each within the scatter of the next, the first and the last beyond it).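

For the compounds shown here, with 1-(ethoxycarbonyl)-1-methylethyl in place of (1H-imidazol-1-yl)methyl on a carbonyl carbon, this assay gives a 1.2-fold higher number from compound 1 to compound 4 (0.09 log units; within the scatter), the first single-change step. In this pair, the position accepts an open-chain ester group with no ring in place of the five-membered aromatic ring without a difference beyond the scatter, so that ring is not needed to keep the number at this level on the core of compound 1. No measurement to hand explains this result.

On these data alone, it remains open whether a dimethylaminomethyl group or a plain butyl chain at this position would also stay within the scatter of compound 1. This step also rests on one pair, so whether it carries over to the core of compound 2 is unresolved.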